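Swapping a Chlorophenyl for a Trimethoxyphenyl on the Core

The source may report more compounds than this note shows. Statements on the series, on what has been measured and on what is new or still open speak of the compounds shown alone.

Measured so far:
Compound 1 `Cc1cc(O)c(C2=NN(c3ccc(S(N)(=O)=O)cc3)C(c3ccccc3O)C2)cc1Cl`: 13000 nM
Compound 2 `Cc1cc(O)c(C2=NN(c3ccc(S(N)(=O)=O)cc3)C(c3ccccc3Cl)C2)cc1Cl`: 8220 nM

Within the data shown here, in a functional assay on RXF 393 cells (Homo sapiens) for antiproliferative activity, with a stated time of 48 h (on this read-out higher numbers stand for weaker inhibition of growth and lower numbers for stronger inhibition of growth), compound 2 stands alongside compound 1: the single known step, a 1.6-fold lower number from compound 1 to compound 2 (0.20 log units; within the scatter), lies within the scatter, so the two cannot be ranked. Compound 3 `COc1ccc(C2CC(c3cc(Cl)c(C)cc3O)=NN2c2ccc(S(N)(=O)=O)cc2)c(OC)c1OC` differs from compound 2 by 2,3,4-trimethoxyphenyl in place of 2-chlorophenyl on a saturated ring carbon. Among the measured compounds shown here, the one measured step altered a different ring of the shared core, and it was small, so it gives no direct guide to this new exchange. No step beyond the scatter is therefore expected. Compound 3 is estimated at 10000 nM, within the range 3000 nM to 35000 nM, which means an expected step of a 1.2-fold higher number from compound 2 to compound 3 (0.09 log units; within the scatter).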

Compound 3, concentration for total growth inhibition: 6020 nM
For compound 3 the middle estimate is 1.7-fold (0.22 log units) above the measured one, within the range that was stated.
By their numbers in this assay, from the lowest: compounds 3, 2 and 1 (each within the scatter of the next, the first and the last beyond it).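

In this assay, this saturated ring carbon tolerates 2,3,4-trimethoxyphenyl: exchanging 2-chlorophenyl for it gives a 1.4-fold lower number from compound 2 to compound 3 (0.14 log units; within the scatter), so the two compounds cannot be ranked. Among these compounds, exchanging 2-hydroxyphenyl for it gives a 2.2-fold lower number from compound 1 to compound 3 (0.33 log units; beyond the scatter), the first step in this set that clears the scatter, though only modestly. Nothing available here accounts for that step.

The compounds shown leave open whether all of the methoxy groups are needed for this result. They also leave open whether an amine or a carboxylic acid on this phenyl ring would shift growth inhibition further.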